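A Chloromethylphenyl Variant of Compound 1 Is Weighed Up

The compounds below may be only part of what the source reports. "The series", "measured", "known", "first", "only" and "open" are said of these compounds alone.

Measured so far:
compound 1, `O=C(Nc1cccnc1)c1ccccc1OCc1ccccc1Cl`: 1100 nM
compound 2, `O=C(Nc1cccnc1)c1ccccc1OCc1cccc(Cl)c1`: 1400 nM
compound 3, `N#Cc1cccc(COc2ccccc2C(=O)Nc2cccnc2)c1`: 60700 nM

In an assay on lysate for inhibition of phosphatidylcholine:ceramide cholinephosphotransferase 2 (Homo sapiens), read by HPLC, with stated times of 30 min and 2 h (on this read-out lower numbers stand for stronger inhibition and higher numbers for weaker inhibition), compound 1 gives the lowest of the three numbers, yet the step of a 1.3-fold higher number from compound 1 to compound 2 (0.10 log units; within the scatter) lies within the scatter, so compound 1 and compound 2 cannot be told apart. Compound 3 sits far off, with a 55-fold higher number from compound 1 to compound 3 (1.74 log units; beyond the scatter) and a 43-fold higher number from compound 2 to compound 3 (1.64 log units; beyond the scatter). Compound 4, `Cc1c(Cl)cccc1COc1ccccc1C(=O)Nc1cccnc1`, differs from compound 1 thus: 3-chloro-2-methylphenyl in place of 2-chlorophenyl on a saturated chain carbon bound to an oxygen on an aromatic ring. For the measured compounds named here, the step that bears on it is a 1.3-fold higher number from compound 1 to compound 2 (0.10 log units; within the scatter), where 3-chlorophenyl replaced 2-chlorophenyl without effect; no measured step shows the added methyl. The large steps to compound 3 concern a cyano group and do not apply here. Compound 4 is therefore expected to give about 900 nM, in the range 300 nM to 3000 nM. The expected step of a 1.2-fold lower number from compound 1 to compound 4 (0.09 log units; within the scatter) should stay within the scatter.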

Compound 4, half-maximal inhibitory concentration: 3800 nM
Beside the measured number, compound 4's estimate is 4.2-fold (0.63 log units) below it, outside the stated range (above it).
By their numbers in this assay, from the lowest: compounds 1 and 2 (each within the scatter of the next); then compound 4; then compound 3.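

In this assay this position responds to a small addition that the swap of chlorophenyl groups gave no hint of: methyl in place of hydrogen on an aromatic carbon raises the number (a 2.7-fold higher number from compound 2 to compound 4 (0.43 log units; beyond the scatter)), and the new group also stands apart from the 2-chlorophenyl of compound 1 (a 3.5-fold higher number from compound 1 to compound 4 (0.54 log units; beyond the scatter)). Even so, the change from the 3-cyanophenyl group recovers much of the gap (a 16-fold lower number from compound 3 to compound 4 (1.20 log units; beyond the scatter)). Nothing at hand accounts for these differences.

On these data alone, what a methoxy group or an amine would do in place of that methyl remains open, as does the effect of a methyl on the 2-chlorophenyl group of compound 1.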